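A few compounds are considered here, and "the series" means these few. Any claim that something is new, unique, unknown or untested is made for them only; others in the source may bear on it.

Measured so far:
- compound 1, `Nc1ccccc1NC(=O)c1ccc(CSC(=S)N2CCN(c3ccc(F)cc3)CC2)cc1`, gives 76.3% in a functional assay on A-375 cells (Homo sapiens) for antiproliferative activity, read by CCK-8 assay, with a stated time of 72 h, tested at 8 uM; a higher number here means a stronger effect of the compound at the concentration tested, a lower number a weaker effect
- compound 2, `Nc1ccccc1NC(=O)c1ccc(CSC(=S)N2CCN(Cc3ccncc3)CC2)cc1`, gives 89.5% in this assay

Within the data shown here, of these two numbers, compound 2 stands highest; its only neighbour is compound 1, and the step of a number 13.2 percentage points higher from compound 1 to compound 2 (beyond the scatter) lies beyond the scatter, though it is modest in size. Compound 3, `Cc1ccc(N2CCN(C(=S)SCc3ccc(C(=O)Nc4ccccc4N)cc3)CC2)cc1`, has not yet been measured. It differs from compound 2 in one place: 4-methylphenyl in place of (pyridin-4-yl)methyl on an amine nitrogen in a ring. The group that enters is, like the 4-fluorophenyl of compound 1, a six-membered aromatic ring of carbon only set directly on the amine nitrogen in the ring, so the change largely undoes the step that separated compound 1 from compound 2. Among the measured compounds shown here, the only measured step that bears on it is the one from compound 1 to compound 2, which favoured the (pyridin-4-yl)methyl group. Going back the other way, a modest fall is expected: a number 11.5 percentage points lower from compound 2 to compound 3 (beyond the scatter). For the measured compounds named here, whether 4-methylphenyl behaves like 4-fluorophenyl cannot be checked, as no measured pair shows that swap. Compound 3 is therefore estimated at 78%, with a likely range from 62% to 92%.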

Compound 3, a percentage reported as inhibition, at one concentration (the size of the read-out at that concentration, not a potency): 26.4%
Compound 3: middle estimate off by 51.6 percentage points, on the high side; measured number outside the range, below it.
By their numbers in this assay, from the lowest: compound 3; then compound 1; then compound 2.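

The sharpest finding is that this position does not treat all carbon-only aromatic rings on the ring nitrogen alike: with methyl in place of fluoro on an aromatic carbon, this assay gives a number 49.9 percentage points lower from compound 1 to compound 3 (beyond the scatter), so a change of one small group can matter a great deal here. The swap of (pyridin-4-yl)methyl for 4-methylphenyl gives a number 63.1 percentage points lower from compound 2 to compound 3 (beyond the scatter), far larger than the modest a number 13.2 percentage points higher from compound 1 to compound 2 (beyond the scatter), even though the group that leaves and the group that enters each count the same number of heavy atoms, so that count alone does not separate them. Nothing in the information available explains why either change has so large an effect.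

The compounds shown leave open whether the low number belongs to methyl in particular, which an unsubstituted phenyl, a 4-chlorophenyl or a 4-methoxyphenyl on the same nitrogen would help to settle. A benzyl group would also help to separate the role of the ring nitrogen in (pyridin-4-yl)methyl from that of the single carbon joining this ring to the amine nitrogen.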